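A few compounds are considered here, and "the series" means these few. Any claim that something is new, unique, unknown or untested is made for them only; others in the source may bear on it.

The series shares the core of compound 1 `COc1ccc(N2C(=O)COc3ccc(-c4cnc5ccccc5c4)cc32)cc1`. In a functional assay on A-375 cells (Homo sapiens) for antiproliferative activity, read by MTT assay, with a stated time of 72 h (a lower number here means a stronger inhibitor, a higher number a weaker inhibitor), compound 1 reaches only the limit of the assay, > 40000 nM. Compound 3 `O=C1COc2ccc(-c3cnc4ccccc4c3)cc2N1` likewise gives only a limit there, > 40000 nM. The step that the two limits leave unreadable from compound 1 to compound 3 is accordingly not readable in size. Within the data shown here, compound 2 `COc1ccc(N2C(=O)COc3ccc(-c4cnc(OC)c(NS(=O)(=O)c5ccc(F)cc5)c4)cc32)cc1` supplies the only number in this assay, giving 18400 nM; the other two values of the set sit at the limit of > 40000 nM in this assay, at which 2 of the 3 values shown sit. Compound 4 `COc1ncc(-c2ccc3c(c2)N(c2ccc(Cl)cc2)C(=O)CO3)cc1NS(=O)(=O)c1ccc(F)cc1` differs from compound 2 by chloro in place of methoxy on an aromatic carbon. Among the measured compounds shown here, no measured step of the set touches this position, and the one step that does exist cannot be read, so the data give no direction for the change. Compound 4 is expected to show a step of a 1.0-fold lower number from compound 2 to compound 4 (0.01 log units; within the scatter) that stays within the scatter. Compound 4 is estimated at 18000 nM, within 6000 nM to 50000 nM.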

Compound 4, half-maximal inhibitory concentration: 24100 nM
Estimate against measurement, compound 4: 1.3-fold (0.13 log units) below, and the stated range covers the measured number.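

Chloro in place of methoxy on an aromatic carbon, para to a large group, gives the only readable step of the series in this assay: a 1.3-fold higher number from compound 2 to compound 4 (0.12 log units; within the scatter). This position therefore accepts either group with no change beyond the scatter. Compound 2 and compound 4 both keep a measured number, whereas the other two compounds give only a limit: the limit of > 40000 nM in this assay, at which 2 of the 4 values shown sit.

As far as these compounds go, whether an amine or a carboxylic acid at this position would move the number beyond the scatter stays open. The step that ends at a limit cannot be read.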